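The source may hold more compounds than are shown below. What is called first, only, known or untested is meant among the compounds shown, and "the series" means these compounds.

Measured so far in an ADME assay on microsomes from liver (Mus musculus, strain CD1) for metabolic stability, read by LC-MS, using NADPH, with a stated time of 60 min; a higher number here means that the compound lasts longer, a lower number that the compound disappears faster:
- compound 1 `COc1ccc(-c2c(-c3ccc(OC)cc3)n(Cc3ccccc3)c3ncn(CCCO)c(=N)c23)cc1`: 0.36 h
- compound 2 `COc1ccc(Cn2c(-c3ccccc3)c(-c3ccccc3)c3c(=N)n(CCCO)cnc32)cc1`: 0.332 h
- compound 3 `COc1ccc(Cn2c(-c3ccccc3)c(-c3ccccc3)c3c(=N)n(CCO)cnc32)cc1`: 0.518 h

Compound 3 carries the change hydroxy in place of hydroxymethyl on a saturated chain carbon, two bonds along the chain from an aromatic nitrogen relative to compound 2, and this gave a 1.6-fold higher number from compound 2 to compound 3 (0.19 log units; within the scatter). The difference between the core of compound 1 and the core of compound 2 is not broken down here; their two values in this assay sit close together. Compound 4 `COc1ccc(-c2c(-c3ccc(OC)cc3)n(Cc3ccccc3)c3ncn(CCO)c(=N)c23)cc1`, not yet measured, carries the same change as hydroxy in place of hydroxymethyl on a saturated chain carbon, two bonds along the chain from an aromatic nitrogen on compound 1; the place is the same in words for both pairs. Among the compounds with values here, the expectation rests on the one earlier step, which was small, so the estimated step of a 1.4-fold higher number from compound 1 to compound 4 (0.14 log units; within the scatter) is kept modest. Compound 4 is expected to give about 0.5 h in this assay, with a range of 0.25 h to 1 h.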

Compound 4, half-life: 1.22 h
The estimate for compound 4 lay 2.4-fold (0.39 log units) below the measured number, and the stated range ends below it.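

On the core of compound 1, 2-hydroxyethyl in place of 3-hydroxypropyl gives a 3.4-fold higher number from compound 1 to compound 4 (0.53 log units; beyond the scatter) in this assay. Set beside the same change on the other core, the two steps cannot be told apart, so the data give no sign that the change behaves differently on these two cores: the same change on two cores in this assay, a 1.6-fold higher number (0.19 log units; within the scatter) from compound 2 to compound 3 and a 3.4-fold higher number (0.53 log units; beyond the scatter) from compound 1 to compound 4, 2.2-fold (0.34 log units) apart, within the scatter of two such steps. Within the data shown here, this does not show a fixed step size across the series, since only two cores are compared and only the step on the core of compound 1 lies beyond the scatter.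

Going by these compounds, it remains open whether the change carries to further cores. Also open, on these data alone, is how a chain longer than 3-hydroxypropyl, or an amine or a carboxylic acid in place of the hydroxy, would read in this assay.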